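The compounds below may be only part of what the source reports. "The series", "measured", "known", "first", "only" and "open" are said of these compounds alone.

Measured compounds:
compound 1, `CCCNS(=O)(=O)c1ccc(Nc2ncc3c(n2)N(c2ccn(C)n2)C(CC)C(=O)N3C)cc1`, 21700 nM in a functional assay on NCI-H1975 cells (Homo sapiens) for antiproliferative activity, read by CCK-8 assay, with a stated time of 72 h; a higher number here means a weaker inhibitor of growth, a lower number a stronger inhibitor of growth
compound 2, `CC[C@@H]1C(=O)N(C)c2cnc(-n3ccc4cc(C(=O)NCC(C)C)ccc43)nc2N1C1CCCC1`, "not active" (no number reported) in this assay, with no number given

Within the data shown here, compound 1 is the only compound of the pair with a number: in this assay compound 1 gives 21700 nM, a weak inhibitor of growth by this reading. Compound 2 is a different matter. Among the measured compounds shown here, for compound 2 the outcome in this assay was recorded only as not active, so there is no value to place it on the scale and no step to compound 1 can be computed; the two compounds share a core but differ in several places at once, and nothing more can be said of them together than that both sit at the weak end.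

Compound 3, `CCNC(=O)c1ccc2c(ccn2-c2ncc3c(n2)N(C2CCCC2)[C@H](CC)C(=O)N3C)c1`, has not yet been measured in this assay. It differs from compound 2 in one place: methyl in place of isopropyl on a saturated chain carbon bound to an amide-type nitrogen. For the measured compounds named here, no step between two measured compounds matches this change, so its size is not known from the data. Given that compound 2 was reported as not active, compound 3 is expected to remain a weak inhibitor of growth as well, with no shift beyond the scatter that can be justified from what has been measured.

The estimate for compound 3 in this assay is 30000 nM, expected to fall between 8000 nM and 100000 nM, with a real chance that only a limit is reported.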

Compound 3, concentration for 50% growth inhibition: 882 nM
For compound 3 the middle estimate is 34-fold (1.53 log units) above the measured one; the measured number lies below the stated range.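

No step can be read between compound 2 and compound 3: compound 2 was recorded only as not active in this assay and compound 3 gives 882 nM there. Nothing available accounts for this result. The compounds shown leave open how large a change in growth inhibition isobutylcarbamoyl to ethylcarbamoyl produces on its own.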